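From an amino-methoxy ring to a tert-butyl ring

This account rests on a few compounds, and the source may have more. Where it says the series, first, only, none or still open, it means among the compounds named here.

Measured in a functional assay on A549 cells (Homo sapiens) for inhibition, read by CCK-8 assay, with a stated time of 48 h; on this read-out lower numbers stand for stronger inhibition and higher numbers for weaker inhibition:
- Compound 1 `COc1cc(-c2ccnc3cc(-c4ccc(C)cc4)nn23)cc(OC)c1OC`: 3 nM
- Compound 2 `C=Cc1ccc(-c2cc3nccc(-c4cc(OC)c(OC)c(OC)c4)n3n2)cc1`: 1030 nM
- Compound 3 `COc1ccc(-c2cc3nccc(-c4cc(OC)c(OC)c(OC)c4)n3n2)cc1N`: 138 nM

Compound 3 is the middle member of this small set, with 138 nM the second highest of the three numbers. Compound 4 `COc1cc(-c2ccnc3cc(-c4ccc(C(C)(C)C)cc4)nn23)cc(OC)c1OC` keeps the shared core but carries 4-(tert-butyl)phenyl in place of 3-amino-4-methoxyphenyl on an aromatic carbon.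

Going by the values given here, three measured steps bear on this change. Both departures from the 4-methylphenyl group raised the number by a large margin, first with a 340-fold higher number from compound 1 to compound 2 (2.54 log units; beyond the scatter) and then with a 46-fold higher number from compound 1 to compound 3 (1.66 log units; beyond the scatter). The remaining step, a 7.5-fold lower number from compound 2 to compound 3 (0.87 log units; beyond the scatter), was modest and favoured 3-amino-4-methoxyphenyl over 4-vinylphenyl. The incoming group resembles 4-vinylphenyl in being a phenyl ring with one carbon-only substituent, so a modest rise in this assay is expected, though with wide uncertainty.

The estimated change is a 5.1-fold higher number from compound 3 to compound 4 (0.71 log units; beyond the scatter). For compound 4 the expected value is 700 nM, with an estimated range of 90 nM to 5000 nM.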

Compound 4, half-maximal inhibitory concentration: > 10000 nM
Compound 4: no number, only a limit; the forecaster's own chance of this, stated with the estimate: 5%; at least 14-fold (1.15 log units) between middle value and limit.
By their numbers in this assay, from the lowest: compound 1; then compound 3; then compound 2. At a limit, above all of these: compound 4.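

Compound 4 gives no exact number in this assay, only a limit: the limit of > 10000 nM in this assay, at which 1 of the 4 values shown sits.

Changing only methyl to tert-butyl gives an at least 3300-fold higher number from compound 1 to compound 4 (3.52 log units; beyond the scatter), so this position does not treat all alkyl groups on the phenyl ring alike, which the vinyl change alone could not establish. The other two comparisons point the same way, with an at least 72-fold higher number from compound 3 to compound 4 (1.86 log units; beyond the scatter) and an at least 9.7-fold higher number from compound 2 to compound 4 (0.98 log units; beyond the scatter), so the 4-(tert-butyl)phenyl ring, with its 0 hydrogen-bond donors and 0 hydrogen-bond acceptors, stands above both of the weaker groups seen earlier.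

The compounds shown leave open how ethyl or isopropyl in place of methyl would read on the same ring, and so whether the rise sets in gradually or abruptly. They also cannot tell how far beyond the limit the true value of compound 4 lies.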